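The source may report more compounds than this note shows. Statements on the series, on what has been measured and on what is new or still open speak of the compounds shown alone.

Three compounds sharing one core have numbers in an ADME assay on MT4 cells (Homo sapiens) for cytotoxicity, read by MTT assay; on this read-out lower numbers stand for higher toxicity in this test and higher numbers for lower toxicity in this test: compound 1 `Cc1cc(C)cc(S(=O)(=O)c2c(C(=O)Nc3cccc(O)c3)[nH]c3ccc(Cl)cc23)c1`, compound 2 `Cc1cc(C)cc(S(=O)(=O)c2c(C(=O)NC(C)c3cccc(O)c3)[nH]c3ccc(Cl)cc23)c1` and compound 3 `Cc1cc(C)cc(S(=O)(=O)c2c(C(=O)Nc3ccc(CO)cc3)[nH]c3ccc(Cl)cc23)c1`. Here compound 1 gives 24600 nM, compound 2 gives 16000 nM and compound 3 gives 39600 nM. Compound 3 stands level with one neighbour, given a 1.6-fold higher number from compound 1 to compound 3 (0.21 log units; within the scatter), and clear of the other, given a 2.5-fold higher number from compound 2 to compound 3 (0.39 log units; beyond the scatter).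

Compound 4 `Cc1cc(C)cc(S(=O)(=O)c2c(C(=O)NCc3ccc(O)c(O)c3)[nH]c3ccc(Cl)cc23)c1` has not yet been measured. Its difference from compound 3 is 3,4-dihydroxybenzyl in place of 4-(hydroxymethyl)phenyl on an amide-type nitrogen; in words, 3,4-dihydroxybenzyl in place of 4-(hydroxymethyl)phenyl on an amide-type nitrogen. Going by the values given here, no measured step makes this exact exchange, so the only guide is the three steps at that same nitrogen. Among the compounds with values here, the remaining one is a 1.5-fold lower number from compound 1 to compound 2 (0.19 log units; within the scatter), and together they show small movement, with only one step passing the scatter, and that modestly.

A small step is therefore expected in this assay, perhaps none beyond the scatter. Within the data shown here, the weak lean is toward a lower number, because a 2.5-fold higher number from compound 2 to compound 3 (0.39 log units; beyond the scatter) is the only step beyond the scatter, and it leaves compound 3 as the higher of that pair. The expected change is a 1.8-fold lower number from compound 3 to compound 4 (0.26 log units; within the scatter). For compound 4 the estimated value is 22000 nM, with an expected range from 9000 nM to 45000 nM.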

Compound 4, half-maximal cytotoxic concentration: 18300 nM
Estimate against measurement, compound 4: 1.2-fold (0.08 log units) above; low and high end bracket the measured number.
By their numbers in this assay, from the lowest: compounds 2, 4, 1 and 3 (each within the scatter of the next, the first and the last beyond it).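

In this assay the exchange gives a 2.2-fold lower number from compound 3 to compound 4 (0.34 log units; beyond the scatter) and so becomes the second step at this amide-type nitrogen to pass the scatter, with compound 3 again the higher of the pair. Compound 4 stays level with the other two, since the change gives a 1.1-fold higher number from compound 2 to compound 4 (0.06 log units; within the scatter) and the further change gives a 1.3-fold lower number from compound 1 to compound 4 (0.13 log units; within the scatter), so 3,4-dihydroxybenzyl does not separate from 3-hydroxyphenyl or from the group on compound 2. Both steps beyond the scatter now end at compound 3, yet compound 1 goes against any picture of compound 3 standing apart from the whole set, as a 1.6-fold higher number from compound 1 to compound 3 (0.21 log units; within the scatter) stays within it, and nothing available explains these small differences.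

Compound 4 differs from compound 3 in both the attachment of the ring and the oxygen groups on it, so a plain benzyl or a 4-hydroxybenzyl group on this nitrogen would be needed to tell these apart. On these data alone, whether an amine, a carboxylic acid or a longer chain at the same place would move the number in this assay further than these steps remains open.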